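The source may report more compounds than this note shows. Statements on the series, on what has been measured and on what is new or still open speak of the compounds shown alone.

Compound 1 `O=C(O)COCCCCC1=CCC[C@@H]1NS(=O)(=O)c1ccc(Cl)c(Cl)c1`: in a functional assay on a cell-free system (plasma) for inhibition of thromboxane A2 receptor (Homo sapiens), read by turbidimetry (on this read-out lower numbers stand for stronger inhibition and higher numbers for weaker inhibition), compound 1 gives 1900 nM.
Compound 2 `O=C(O)CC/C=C\CC1=CCC[C@@H]1NS(=O)(=O)c1ccc(Cl)c(Cl)c1`: in this assay compound 2 gives 1900 nM.

Compound 1 and compound 2 share a core and the same dichlorinated aromatic ring; they differ only in the side chain that carries the acid. That single step, 4-carboxybut-1-en-1-yl in place of 3-(carboxymethoxy)propyl on a saturated chain carbon bound to a double-bonded ring carbon, gave no change at the digits printed from compound 1 to compound 2 (within the scatter). Compound 2 therefore stands level with compound 1 at the digits shown, and nothing separates the two beyond the usual scatter.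

Compound 3 `O=C(O)CC/C=C\CC1=CCC[C@@H]1NS(=O)(=O)c1ccc(Cl)cc1` has not yet been measured. It keeps the side chain of compound 2 and changes the aromatic ring: hydrogen in place of chloro on an aromatic carbon. Within the data shown here, no measured step touches this ring; the one step available, from compound 1 to compound 2, concerns only the chain, so it gives no guide to the size or direction of this change. The expectation rests on compound 2 alone, and the range is set wide. On that basis compound 3 is expected to give about 2500 nM, somewhere between 900 nM and 8000 nM, which is a step of a 1.3-fold higher number from compound 2 to compound 3 (0.12 log units; within the scatter), not clearly beyond the scatter.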

Compound 3, half-maximal inhibitory concentration: 1900 nM
Compound 3: middle estimate off by 1.3-fold (0.12 log units), on the high side, and the stated range covers the measured number.
By their numbers in this assay, from the lowest: compounds 1, 2 and 3 (each within the scatter of the next).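

Taking away one chloro group, which turns 3,4-dichlorophenyl into 4-chlorophenyl, gave no change at the digits printed from compound 2 to compound 3 (within the scatter) in this assay. Among these compounds, this is the first measured step on the aromatic ring rather than on the acid-bearing chain, and it shows that, with the 4-carboxybut-1-en-1-yl chain in place, the chloro group ortho to the remaining chloro group can be replaced by hydrogen with no change that this read-out can separate from the scatter. No measurement shown here offers an explanation for this result.

On these data alone, the remaining chloro group is still untested, so its own contribution is unknown, as is the outcome of a ring carrying no chlorine at all or of a methoxy group, a nitrile or a trifluoromethyl group at the position studied here. It is also open whether the same swap of chloro for hydrogen would leave the number unchanged with the 3-(carboxymethoxy)propyl chain of compound 1, since no step shown combines that chain with the 4-chlorophenyl ring.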